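The source may report more compounds than this note shows. Statements on the series, on what has been measured and on what is new or still open speak of the compounds shown alone.

Measured compounds:
Compound 1 `Cc1ccnc(/C(N)=N/NC(=S)N2CCCC2)c1` — 82.2%
Compound 2 `Cc1ccnc(/C(N)=N/NC(=S)N2CCOCC2)c1` — 8.16%
Compound 3 `Cc1ccnc(/C(N)=N/NC(=S)N2CCN(c3ccccn3)CC2)c1` — 63.8%

In a functional assay on MCF7 cells (Homo sapiens) for cytotoxicity, read by MTT assay, with a stated time of 72 h, tested at 30 uM (on this read-out lower numbers stand for less inhibition of growth and higher numbers for more inhibition of growth at the one concentration tested), compound 3 stands second highest of the three, with compound 1 above it beyond the scatter and compound 2 far below it. Compound 4 `N/C(=N\NC(=S)N1CCN(c2ccccn2)CC1)c1ccccn1` differs from compound 3 by hydrogen in place of methyl on an aromatic carbon. Going by the values given here, the one measured step, a number 74 percentage points lower from compound 1 to compound 2 (beyond the scatter), concerns the group on the thiocarbonyl carbon, not the aromatic ring, so no measured step bears directly on this change. Removing one carbon from the ring is therefore expected to give no step beyond the scatter. The expected step is a number 5.8 percentage points lower from compound 3 to compound 4 (within the scatter). Compound 4 is estimated at 58%, with a range from 35% to 80%.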

Compound 4, percent growth inhibition at one concentration: 65.3%
Compound 4: the middle estimate sits 7.3 percentage points below what was measured; the range from low to high includes it.
By their numbers in this assay, from the lowest: compound 2; then compounds 3 and 4 (each within the scatter of the next); then compound 1.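

Exchanging 4-methylpyridin-2-yl for pyridin-2-yl gives a number 1.5 percentage points higher from compound 3 to compound 4 (within the scatter) in this assay, so in this pair the methyl is not needed to retain this level of growth inhibition. This is the only measured change on the aromatic ring among the compounds shown, and it rests on a single pair with the same group on the thiocarbonyl carbon. No available evidence accounts for this result. From the compounds shown here alone, it remains open how an amine, a methoxy group or a longer chain would read at this position. Going by these compounds, it also remains open whether the same exchange would read alike with pyrrolidin-1-yl on the thiocarbonyl carbon.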